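Saturating the Acyl Group: (1-Methylethenyl)carbonyl to Propanoyl

This account rests on a few compounds, and the source may have more. Where it says the series, first, only, none or still open, it means among the compounds named here.

Measured compounds:
compound 1, `C/C=C/C(=O)N(Cc1ccc(OC)c([N+](=O)[O-])c1)c1cc(OC)c(OC)c(OC)c1`: 670 nM
compound 2, `C=C(C)C(=O)N(Cc1ccc(OC)c(O)c1)c1cc(OC)c(OC)c(OC)c1`: 200 nM

Both compounds were tested in a functional assay on HCT-116 cells (Homo sapiens) for inhibition, read by MTT assay, with a stated time of 48 h; on this read-out lower numbers stand for stronger inhibition and higher numbers for weaker inhibition. Of the two numbers, compound 2 gives the lower one, and the gap to compound 1 lies beyond the scatter; the two compounds differ in several places, so only the values themselves can be compared.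

Compound 3, `CCC(=O)N(Cc1ccc(OC)c(O)c1)c1cc(OC)c(OC)c(OC)c1`, has not yet been measured. It differs from compound 2 in one place: ethyl in place of 1-methylethenyl on a carbonyl carbon. Within the data shown here, no measured pair shows this exact change, so the expected size of the step rests only on the shared core and on compound 2 with its value of 200 nM.

Compound 3 is expected to give a somewhat higher number than compound 2, a step of a 2.5-fold higher number from compound 2 to compound 3 (0.40 log units; beyond the scatter) that may reach beyond the scatter. The estimate for compound 3 is 500 nM, within a range of 150 nM to 2000 nM.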

Compound 3, half-maximal inhibitory concentration: 61 nM
For compound 3 the middle estimate is 8.2-fold (0.91 log units) above the measured one; measured number outside the range, below it.
By their numbers in this assay, from the lowest: compound 3; then compound 2; then compound 1.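

In this assay, among these compounds, replacing 1-methylethenyl with ethyl on the carbonyl carbon gives a 3.3-fold lower number from compound 2 to compound 3 (0.52 log units; beyond the scatter), the first comparison at this position in which only one place changes. The 1-methylethenyl group, with its double bond and one more carbon, is therefore not needed for a low number here: the smaller, saturated ethyl group gives the lower value of this pair. Nothing available explains the size or direction of this step.

This single pair changes the double bond and the carbon count together, so it cannot show which of the two matters. A 1-methylethyl group on the same carbonyl carbon would keep the carbon count without the double bond, while methyl or a longer propyl chain would show how the number follows chain length.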